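Methyl on the amide nitrogen: compound 2 to compound 4

A few compounds are considered here, and "the series" means these few. Any claim that something is new, unique, unknown or untested is made for them only; others in the source may bear on it.

Compound 2 `CC(=O)NCC#CCn1ccnc1` gives > 100 mg/kg in a functional assay on the whole organism for agonist activity, with Mus musculus as the target (on this read-out higher numbers stand for an effect only at larger amounts of compound and lower numbers for an effect already at smaller amounts), and this is a limit, not a number. Compound 3 `CC(=O)NCC#CCn1cncc1C` gives > 100 mg/kg in this assay, which is again a limit. Compound 2 therefore stands at the limit of > 100 mg/kg in this assay, at which 2 of the 3 values shown sit.

The change under consideration leads to compound 4 `CC(=O)N(C)CC#CCn1ccnc1`: methyl in place of hydrogen on an amide-type nitrogen, that is, a methyl in place of hydrogen on an amide-type nitrogen. Going by the values given here, the one measured step is a step that the two limits leave unreadable from compound 2 to compound 3. It concerns a methyl in place of hydrogen on an aromatic carbon, and it supplies no size to carry over.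

Among the compounds with values here, the only numerical guide is compound 1 `CC(=O)N(C)C(C)C#CCn1ccnc1`, which also carries a methyl on an amide-type nitrogen and gives 2 mg/kg in this assay. Within the data shown here, no measured step isolates the change itself, so this supports a direction more firmly than a size, and the uncertainty stays wide. The expected step is an at least 5.0-fold lower number from compound 2 to compound 4 (0.69 log units; beyond the scatter), towards an effect at smaller amounts of compound. Another result reported only as a limit remains possible. For compound 4 the estimated value is 20 mg/kg, with an expected range from 4 mg/kg to 100 mg/kg.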

Compound 4, dose for half-maximal effect: 0.97 mg/kg
Compound 4: middle estimate off by 21-fold (1.31 log units), on the high side, outside the stated range (below it).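

Methyl in place of hydrogen on the amide-type nitrogen gives an at least 100-fold lower number from compound 2 to compound 4 (2.01 log units; beyond the scatter) in this assay, so this position carries a large effect, whereas the step from compound 2 to compound 3, with its methyl on an aromatic carbon, cannot be read. Compound 2 stays a limit, so the size of this step is a bound and not an exact difference: the limit of > 100 mg/kg in this assay, at which 2 of the 4 values shown sit.

The methyl on the saturated chain carbon bound to an amide-type nitrogen and a triple-bonded carbon counts for far less once the amide methyl is present: hydrogen in its place gives a 2.1-fold lower number from compound 1 to compound 4 (0.31 log units; beyond the scatter), a modest step.

An ethyl group or a longer chain on the amide-type nitrogen would show whether the gain is tied to methyl itself or extends to larger groups at this position. The compounds shown also leave open whether a methyl on the aromatic carbon, as carried by compound 3, changes the read-out when the amide-type nitrogen also carries methyl.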